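Swapping the Aryl Sulfonyl Group: Compound 2 to Compound 3

The source may hold more compounds than are shown below. What is called first, only, known or untested is meant among the compounds shown, and "the series" means these compounds.

The study compares sulfonamides that share one core. Compound 1 `COc1ccccc1S(=O)(=O)Nc1ccc2oc(-c3ccccc3)nc2c1` carries a 2-methoxyphenyl on the sulfonyl sulfur. In an assay on cells for inhibition of HSP60/HSP10 (Homo sapiens), with a stated time of 60 min (on this read-out higher numbers stand for weaker inhibition and lower numbers for stronger inhibition), compound 1 reaches only a limit of > 100000 nM. Compound 2 `O=S(=O)(Nc1ccc2oc(-c3ccccc3)nc2c1)c1ccc(O)cc1` carries a 4-hydroxyphenyl there instead, and in this assay compound 2 gives 88000 nM, the only number shown. The other value, that of compound 1, is a limit (the limit of > 100000 nM in this assay, at which 1 of the 2 values shown sits). The step of an at least 1.1-fold lower number from compound 1 to compound 2 (0.05 log units; that floor lies within the scatter) lies within the scatter.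

Compound 3 `O=S(=O)(Nc1ccc2oc(-c3ccccc3)nc2c1)c1ccc(Cl)c(Cl)c1` differs from compound 2 by 3,4-dichlorophenyl in place of 4-hydroxyphenyl on a sulfonyl sulfur. Within the data shown here, no measured step follows this exchange; the single step, from compound 1 to compound 2, concerns another group on the same sulfur and stayed within the scatter. No shift beyond the scatter is therefore expected, with a real chance that only a limit is reported. In this assay compound 3 is estimated at 60000 nM, between 15000 nM and 200000 nM, an expected step of a 1.5-fold lower number from compound 2 to compound 3 (0.17 log units; within the scatter).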

Compound 3, half-maximal inhibitory concentration: > 100000 nM
Compound 3 ended at the assay's limit; the forecaster's own chance of this, stated with the estimate: 35%; at least 1.6-fold (0.22 log units) between middle value and limit.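

Placing 3,4-dichlorophenyl in place of 4-hydroxyphenyl on the sulfonyl sulfur gives an at least 1.1-fold higher number from compound 2 to compound 3 (0.05 log units; that floor lies within the scatter). From the compounds shown here alone, since only this floor can be read, the true size of the step stays unknown, and this second exchange on the same sulfur, like the first, shows no shift beyond the scatter in this assay. Compound 1 and compound 3 both stand at a limit, so the step between them cannot be read, and compound 2 is the only one of the three with a number: the limit of > 100000 nM in this assay, at which 2 of the 3 values shown sit.

The compounds shown leave open whether any group on this sulfur can give a clearly lower number than compound 2 at 88000 nM. Going by these compounds, it also remains open how an amine or a carboxylic acid would read on the phenyl ring in place of the hydroxy group.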